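The compounds below may be only part of what the source reports. "The series", "measured", "known", "first", "only" and "open" are said of these compounds alone.

So far, two compounds sharing one core have been measured in a functional assay on MCF7 cells (Homo sapiens) for inhibition, read by MTT assay, with a stated time of 48 h; a higher number here means a weaker inhibitor, a lower number a stronger inhibitor. Compound 1 `CCOC(=O)C1=C(N/N=C(/C(=O)Br)c2ccc(Br)cc2)Nc2[nH]nc(C)c2C1c1ccc(N(C)C)cc1` gives 61300 nM, and compound 2 `CCOC(=O)C(=NNC1=C(C(=O)OCC)C(c2ccc(N(C)C)cc2)c2c(C)n[nH]c2N1)C(=O)OCC` gives 89800 nM. These two values lie within the scatter of each other, so neither compound can be ranked ahead of the other.

The next compound, compound 3 `CCOC(=O)C1=C(N/C=N/c2ccc([N+](=O)[O-])cc2)Nc2[nH]nc(C)c2C1c1ccc(N(C)C)cc1`, keeps the core of compound 2 but differs on an amine nitrogen: a group of 11 heavy atoms (7 carbon, 2 nitrogen, 2 oxygen; one six-membered aromatic ring of carbon only) in place of a group of 12 heavy atoms (7 carbon, 1 nitrogen, 4 oxygen; no ring), on an amine nitrogen. The incoming group carries one six-membered aromatic ring of carbon only, while the outgoing group has no ring.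

Within the data shown here, one measured step bears on this change: a 1.5-fold higher number from compound 1 to compound 2 (0.17 log units; within the scatter). It also exchanged a group with such a ring for the same ringless group, although the ring-bearing group there was a different one. On that evidence, no step beyond the scatter is expected in this assay, and the estimated change is a 1.5-fold lower number from compound 2 to compound 3 (0.18 log units; within the scatter). A single step is thin evidence, so the range is kept wide. For compound 3 the expected value is 60000 nM, with an estimated range from 20000 nM to 150000 nM.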

Compound 3, half-maximal inhibitory concentration: 58600 nM
Estimate against measurement, compound 3: 1.0-fold (0.01 log units) above; the range from low to high includes it.
By their numbers in this assay, from the lowest: compounds 3, 1 and 2 (each within the scatter of the next).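

Among these compounds, compound 3 is the first compound here to put a ring-bearing group without bromine in place of the ringless group of compound 2, and in this assay this exchange stays within the scatter (a 1.5-fold lower number from compound 2 to compound 3 (0.19 log units; within the scatter)). Among the compounds shown here, it also gives the first exchange of one ring-bearing group for another on this amine nitrogen, and that too stays within the scatter (a 1.0-fold lower number from compound 1 to compound 3 (0.02 log units; within the scatter)). The three groups differ in their atoms, in whether they have a ring and in their double bonds outside aromatic rings, yet none of these differences separates the compounds here, and no further data are available to explain this.

On these data alone, all three groups are large, so it remains open whether a much smaller group on this nitrogen, such as a methyl or an acetyl, or a chain ending in a carboxylic acid or an amine, would give a number beyond the scatter. As far as these compounds go, it also remains open whether a change elsewhere on the shared core, for example at the dimethylamino group, would matter more than this one.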